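Pyrazine for Pyridine on the Fused Core

A few compounds are considered here, and "the series" means these few. Any claim that something is new, unique, unknown or untested is made for them only; others in the source may bear on it.

Measured so far, in an assay on isolated protein for inhibition of Leucine-rich repeat serine/threonine-protein kinase 2 (Homo sapiens), in the presence of a further agent that is not named here; a lower number here means a stronger inhibitor, a higher number a weaker inhibitor:
compound 1, `COc1ccc(OC)c(Sc2ccc3nnc(-c4ccccn4)n3n2)c1`: 496 nM
compound 2, `COc1ccc(OC)c(Sc2ccc3nnc(-c4cccnc4)n3n2)c1`: 242 nM

Compound 2 gives the lowest of the two numbers; the step of a 2.0-fold lower number from compound 1 to compound 2 (0.31 log units; beyond the scatter) is modest, though beyond the scatter. Compound 3, `COc1ccc(OC)c(Sc2ccc3nnc(-c4cnccn4)n3n2)c1`, differs from compound 2 by pyrazin-2-yl in place of pyridin-3-yl on an aromatic carbon. For the measured compounds named here, only one measured step bears on this change, and it was modest, so no large shift is expected. The entering ring shares a nitrogen placement with each earlier ring, and the two earlier numbers sit close together. For compound 3 the expected step is a 1.2-fold higher number from compound 2 to compound 3 (0.09 log units; within the scatter), within the scatter. Compound 3 is estimated at 300 nM, with a range of 120 nM to 800 nM.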

Compound 3, half-maximal inhibitory concentration: 880 nM
The estimate for compound 3 lay 2.9-fold (0.47 log units) below the measured number; the measured number lies above the stated range.
By their numbers in this assay, from the lowest: compound 2; then compounds 1 and 3 (each within the scatter of the next).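

In this assay, pyrazin-2-yl does not keep the number given by pyridin-3-yl on this aromatic carbon: a 3.6-fold higher number from compound 2 to compound 3 (0.56 log units; beyond the scatter). Against pyridin-2-yl, the same ring gives a 1.8-fold higher number from compound 1 to compound 3 (0.25 log units; within the scatter), so compound 2 alone separates from the other two, and the position distinguishes among these closely related rings. No available evidence accounts for this difference.

Still open, as far as these compounds go, is whether an amine or a methyl group on the pyridin-3-yl ring would change the number. A plain phenyl ring at this carbon would show how the series behaves without a ring nitrogen.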